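Filling the Ring Nitrogen of Compound 2 with 2-Chlorobenzyl

The source may report more compounds than this note shows. Statements on the series, on what has been measured and on what is new or still open speak of the compounds shown alone.

Compound 2 `CCCCNc1nc(N)nc2c1CNCC2` carries a free amine nitrogen in its saturated ring, and in an assay on HEK293 cells for agonist activity at Toll-like receptor 8 (Homo sapiens), read by a luciferase reporter, with a stated time of 6 h (on this read-out higher numbers stand for an effect only at larger amounts of compound and lower numbers for an effect already at smaller amounts), compound 2 gives 7.2 uM, the highest number of the three measured compounds, with the gap to each of the other two lying beyond the scatter. Compound 1 `CCCCNc1nc(N)nc2c1CCN(Cc1ccccc1)C2`, with a benzyl on the ring nitrogen, gives 0.4 uM in this assay, and compound 3 `CCCCNc1nc(N)nc2c1CCN(S(C)(=O)=O)C2`, with a methylsulfonyl there, gives 0.8 uM. Among the compounds with values here, the one step measured between neighbours, a 2.0-fold higher number from compound 1 to compound 3 (0.30 log units; within the scatter), shows that exchanging one substituent on that nitrogen for another leaves the number essentially where it was.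

Compound 4 `CCCCNc1nc(N)nc2c1CN(Cc1ccccc1Cl)CC2` differs from compound 2 by 2-chlorobenzyl in place of hydrogen on an amine nitrogen in a ring. Within the data shown here, no measured step covers adding a substituent to the bare ring nitrogen; the only guidance is that both substituted compounds, compound 1 and compound 3, give lower numbers than compound 2 by more than the scatter, while the step from compound 1 to compound 3 suggests the identity of the substituent matters little. Compound 4 is therefore expected to show a lower number than compound 2 in this assay, with a step of a 12-fold lower number from compound 2 to compound 4 (1.08 log units; beyond the scatter). The estimate for compound 4 is 0.6 uM, within a range from 0.2 uM to 2 uM.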

Compound 4, minimum effective concentration: 0.05 uM
Estimate against measurement, compound 4: 12-fold (1.08 log units) above, and the stated range ends above it.
By their numbers in this assay, from the lowest: compound 4; then compounds 1 and 3 (each within the scatter of the next); then compound 2.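

In this assay, 2-chlorobenzyl in place of hydrogen on the ring nitrogen gives a 140-fold lower number from compound 2 to compound 4 (2.16 log units; beyond the scatter), a step far beyond the scatter and the first measured on the core of compound 2 itself. Compounds 1 and 3 carry their substituents on a differently built core, so they could only hint at what filling this nitrogen would do, whereas this step isolates the change at this position: with the core held constant, the bare amine nitrogen gives way to a substituted one and the number falls steeply. No measurement shown here bears on why the step is this large.

Still open, on these data alone, is how much of the step belongs to the benzyl and how much to the chlorine on it, and whether the chlorine's place on the aromatic ring matters. Also open, as far as these compounds go, is whether other groups on this nitrogen, such as methyl, acetyl, methylsulfonyl or a longer chain like hexyl, would lower the number in this assay as far on this core, or whether the change is particular to 2-chlorobenzyl.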